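The source may hold more compounds than are shown below. What is called first, only, known or untested is meant among the compounds shown, and "the series" means these compounds.

Measured in a functional assay on MCF7 cells (Homo sapiens) for antiproliferative activity, read by MTT assay; on this read-out lower numbers stand for stronger inhibition and higher numbers for weaker inhibition:
- compound 1 `COc1ccc([C@@H]2[C@@H](C(O)c3ccoc3)C(=O)N2c2cc(OC)c(OC)c(OC)c2)cc1`: 1100 nM
- compound 2 `COc1ccc([C@@H]2C(c3cc4ccccc4s3)C(=O)N2c2cc(OC)c(OC)c(OC)c2)cc1`: 850 nM
- compound 3 `COc1ccc([C@@H]2[C@@H](c3ccsc3)C(=O)N2c2cc(OC)c(OC)c(OC)c2)cc1O`: 10 nM

Compound 1 sits at the weak end of this small set. Its value lies within the usual scatter of compound 2, so these two cannot be ranked against each other. Compound 3, at 10 nM, gives a far lower number, well beyond the scatter.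

The next step leads from compound 1 to compound 4 `COc1ccc([C@@H]2[C@@H](C(=O)c3cccs3)C(=O)N2c2cc(OC)c(OC)c(OC)c2)cc1`, which has not yet been measured. It puts (thiophen-2-yl)carbonyl in place of (furan-3-yl)(hydroxy)methyl on a saturated ring carbon.

Among the compounds with values here, no measured pair shows a change at this place alone. Compound 3 differs from compound 1 in more than one place, so its value says little about this swap. Compound 2, which also has sulfur in the group on that ring carbon, gives 850 nM, and that is the main reason to expect no large shift. The expectation is therefore a small step towards stronger inhibition in this assay, probably not beyond the scatter.

The expected change is a 1.6-fold lower number from compound 1 to compound 4 (0.20 log units; within the scatter).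

For compound 4 the estimated value is 700 nM, with an expected range from 150 nM to 3000 nM.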

Compound 4, half-maximal inhibitory concentration: 950 nM
The estimate for compound 4 lay 1.4-fold (0.13 log units) below the measured number, and the stated range covers the measured number.
By their numbers in this assay, from the lowest: compound 3; then compounds 2, 4 and 1 (each within the scatter of the next).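

In this assay, putting (thiophen-2-yl)carbonyl in place of (furan-3-yl)(hydroxy)methyl on this saturated ring carbon gives a 1.2-fold lower number from compound 1 to compound 4 (0.06 log units; within the scatter), so the two compounds cannot be told apart. Within the data shown here, this is the first direct reading at this position, and it shows that this particular exchange leaves no measurable mark on the result, even though several things differ at once: the furan ring gives way to a thiophene ring, the hydroxy-bearing carbon gives way to a carbonyl, and the hydrogen-bond donor of the leaving group has no counterpart in the entering group. No measurement on hand explains why the result stays within the scatter, so the finding remains a plain observation about this pair.

From the compounds shown here alone, because the ring and the linking carbon differ together, their separate contributions stay unknown, and opposing effects cannot be distinguished from no effect at all; a (furan-3-yl)carbonyl group would separate the two. How far this tolerance extends is also open, since the compounds shown do not reveal what an amine or a carboxylic acid on this ring carbon would do.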